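Moving the methoxy pattern on the pyridine: clearance expected unchanged

The source may report more compounds than this note shows. Statements on the series, on what has been measured and on what is new or still open speak of the compounds shown alone.

Measured compounds:
compound 1, `CCOc1cc([C@](O)(CCN(C)C)[C@@H](c2cc3cc(Br)ccc3nc2OC)c2ccnc(OC)c2OC)cc(OC)n1`, in an ADME assay on microsomes from liver (Mus musculus) for metabolic stability (on this read-out higher numbers stand for fast clearance and lower numbers for slow clearance), compound 1 gives 7.6 uL/min
compound 2, `CCOc1cc([C@](O)(CCN(C)C)[C@@H](c2cc3cc(Br)ccc3nc2OC)c2ccnc(OC)c2OC)cc(OC(C)C)n1`, in this assay compound 2 gives 1.6 uL/min

Among the compounds with values here, compound 2 stands at the lowest of the two numbers; its nearest neighbour is compound 1, and the one step from compound 1 to compound 2 was a 4.8-fold lower number from compound 1 to compound 2 (0.68 log units; beyond the scatter), with isopropyl in place of methyl on an oxygen on an aromatic ring.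

Compound 3, `CCOc1cc([C@](O)(CCN(C)C)[C@@H](c2cc3cc(Br)ccc3nc2OC)c2c(OC)cncc2OC)cc(OC(C)C)n1`, has not been measured. It differs from compound 2 as follows: a group of 10 heavy atoms (7 carbon, 1 nitrogen, 2 oxygen; one six-membered aromatic ring with 1 hetero atom) in place of a group of 10 heavy atoms (7 carbon, 1 nitrogen, 2 oxygen; one six-membered aromatic ring with 1 hetero atom), on a saturated chain carbon bound to an aromatic carbon and a saturated chain carbon. The same atoms are present in both, joined differently, so what changes is only the arrangement on the group that sits on a saturated chain carbon bound to an aromatic carbon and a saturated chain carbon.

Within the data shown here, no measured step touches this part of the molecule; the only step in hand concerns the oxygen substituent on the other ring. There is therefore no basis for expecting a shift beyond the scatter. The step from compound 2 to compound 3 is estimated as no change at the digits printed from compound 2 to compound 3 (within the scatter). Compound 3 is expected to give about 1.6 uL/min, within the range 0.6 uL/min to 4.5 uL/min.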

Compound 3, intrinsic clearance in a liver preparation (reported as CLH), per the amount of preparation that the assay uses: 2.3 uL/min
The estimate for compound 3 lay 1.4-fold (0.16 log units) below the measured number; measured number inside the range.
By their numbers in this assay, from the lowest: compounds 2 and 3 (each within the scatter of the next); then compound 1.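

Within the data shown here, this is the first look at the group on a saturated chain carbon bound to an aromatic carbon and a saturated chain carbon. In this assay, joining the same atoms differently in place of the 2,3-dimethoxypyridin-4-yl group gives a 1.4-fold higher number from compound 2 to compound 3 (0.16 log units; within the scatter) and so leaves the number where compound 2 had it. The earlier step, on the oxygen substituent of the other ring, moved the number beyond the scatter, while this rearrangement does not, and no measurement in hand offers an explanation for the difference between the two changes.

A single rearrangement on a single background cannot show whether a truly different group at this place, such as a plain phenyl ring or a pyridine ring carrying an amine, would also leave the number unchanged. Going by these compounds, it also remains open whether the same rearrangement would behave alike with the methyl on the oxygen of the other ring, as in compound 1, instead of the isopropyl shared by compound 2 and compound 3.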